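Adding a Methoxy Group to Compound 2

The compounds below may be only part of what the source reports. "The series", "measured", "known", "first", "only" and "open" are said of these compounds alone.

Measured so far:
compound 1 `COc1ccc(-c2nc3cc(F)ccc3s2)cc1Cl` — 7050 nM
compound 2 `COc1ccc(-c2nc3cc(F)ccc3s2)cc1O` — 18400 nM

In a functional assay on KM12 cells (Homo sapiens) for antiproliferative activity (on this read-out higher numbers stand for weaker inhibition of growth and lower numbers for stronger inhibition of growth), compound 1 gives 7050 nM, and compound 2 gives 18400 nM. Among the measured compounds shown here, the only step among the measured compounds is a 2.6-fold higher number from compound 1 to compound 2 (0.42 log units; beyond the scatter). Compound 2 therefore stands at the highest of the two numbers, with compound 1 the nearest at the lower end.

Compound 3 `COc1cc(-c2nc3cc(F)ccc3s2)cc(O)c1OC` differs from compound 2 in one place: methoxy in place of hydrogen on an aromatic carbon. For the measured compounds named here, no measured step involves a methoxy group entering in place of hydrogen, so nothing among the two measured compounds bears directly on this change; the step from compound 1 to compound 2 concerns a different exchange at a different place. Going by the values given here, with no guiding precedent, the expectation rests on the small size of the change alone. The step in this assay from compound 2 to compound 3 is expected to be small, a 1.3-fold lower number from compound 2 to compound 3 (0.12 log units; within the scatter), in no particular direction beyond the scatter. Compound 3 is therefore estimated at 14000 nM, within a range of 4500 nM to 45000 nM.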

Compound 3, concentration for 50% growth inhibition: 47500 nM
Estimate against measurement, compound 3: 3.4-fold (0.53 log units) below; measured number above the stated range.
By their numbers in this assay, from the lowest: compound 1; then compound 2; then compound 3.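

In this assay, a methoxy group entering in place of hydrogen on the aromatic carbon ortho to a methoxy group and meta to a hydroxy group gives a 2.6-fold higher number from compound 2 to compound 3 (0.41 log units; beyond the scatter), so growth inhibition weakens with this change. Among the compounds shown here, the earlier compounds spoke only to the exchange of chloro for hydroxy at another place, whereas this step is the first reading of this carbon, and it shows that a group of only 2 heavy atoms entering here moves the number beyond the scatter, in the direction of weaker inhibition. Nothing measured on these compounds explains why the number rises at this position.

The compounds shown leave open whether the loss belongs to methoxy in particular or would follow any group on this carbon, such as fluoro, methyl, an amine or a carboxylic acid, each of which could read differently in this assay. They also leave open whether the same methoxy group would cost as much when chloro stands in place of the hydroxy group, as it does in compound 1.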